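The source may hold more compounds than are shown below. What is called first, only, known or untested is meant among the compounds shown, and "the series" means these compounds.

In a functional assay on HepG2 cells (Homo sapiens) for antiproliferative activity, read by fluorescence and resazurin assay, with a stated time of 48 h (on this read-out lower numbers stand for stronger inhibition and higher numbers for weaker inhibition), compound 1 (`CCOc1ccc(NC(=O)c2cc3cc(Br)ccc3oc2=O)cc1`) gives 37000 nM as its reading. Compound 3 (`Cc1noc(NS(=O)(=O)c2ccc(NC(=O)c3cc4ccccc4oc3=O)cc2)c1C`) gives 24000 nM and lies within the usual scatter of compound 1, so these two cannot be told apart. Compound 2 (`O=C(N/N=C/c1ccncc1)c1cc2cc(Br)ccc2oc1=O`) gives 4890 nM and this reading lies beyond the scatter from compound 1, which places compound 1 at the weak end of this small set. Compound 4 (`CCOc1ccc(NC(=O)c2cc3cc([N+](=O)[O-])ccc3oc2=O)cc1`) keeps the rest of compound 1 but has nitro in place of bromo on an aromatic carbon of the shared core (nitro in place of bromo on an aromatic carbon). Within the data shown here, no two measured compounds differ in only one place, so the data offer no direct guide to this swap. The expectation therefore starts from compound 1 at 37000 nM and foresees no step beyond the scatter in this assay in either direction. The estimated step is a 1.2-fold lower number from compound 1 to compound 4 (0.09 log units; within the scatter) and it stays within the scatter. For compound 4 the estimate is 30000 nM with an expected range from 9000 nM to 80000 nM for repeated measurements.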

Compound 4, half-maximal inhibitory concentration: 28300 nM
The estimate for compound 4 lay 1.1-fold (0.03 log units) above the measured number; the range from low to high includes it.
By their numbers in this assay, from the lowest: compound 2; then compounds 3, 4 and 1 (each within the scatter of the next).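

In this assay, among these compounds, the swap of bromo for nitro on this aromatic carbon of the shared core gives a 1.3-fold lower number from compound 1 to compound 4 (0.12 log units; within the scatter) and so provides the first direct comparison at this position, with two compounds that cannot be told apart. A single bromine atom gives way to a group of three heavy atoms with two hydrogen-bond acceptors, yet the two readings stay within the scatter, so this assay detects no difference between these two groups here. Nothing available explains why they read alike.

Going by these compounds, whether an amine or a methoxy group at this position would also read like bromo and nitro remains open. Also open, on these data alone, is whether the same swap would give a similar result with a different group on the amide nitrogen.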